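Compound 3 to compound 4: a larger group on nitrogen

The source may report more compounds than this note shows. Statements on the series, on what has been measured and on what is new or still open speak of the compounds shown alone.

Compound 1 `COc1ccc([C@H]2CC(=O)N(c3cccc(O)c3)C2)cc1OC1CCCC1`, compound 2 `COc1ccc([C@H]2CC(=O)N(c3cccc(NCC4CCOC4)c3)C2)cc1OC1CCCC1` and compound 3 `COc1ccc([C@H]2CC(=O)N(c3cccc(NC(=O)C(C)=O)c3)C2)cc1OC1CCCC1` share one core and differ in a single substituent. In a functional assay on HEK293 cells (Homo sapiens) for cytotoxicity (on this read-out higher numbers stand for lower toxicity in this test and lower numbers for higher toxicity in this test), compound 1 gives > 10000 nM as a limit of the assay and not a number. In this assay compound 2 gives > 10000 nM as a limit as well. In this assay compound 3 also gives only a limit, > 10000 nM, so its standing carries no number. Compound 4 `COc1ccc(S(=O)(=O)Nc2cccc(N3C[C@@H](c4ccc(OC)c(OC5CCCC5)c4)CC3=O)c2)cc1` carries (4-methoxyphenyl)sulfonyl in place of acetylcarbonyl on a nitrogen on an aromatic ring, with the counted difference (4-methoxyphenyl)sulfonyl in place of acetylcarbonyl on a nitrogen on an aromatic ring marking the change.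

The closest measured precedent is a step that the two limits leave unreadable from compound 2 to compound 3 at that same nitrogen. Neither a step that the two limits leave unreadable from compound 1 to compound 3 nor a step that the two limits leave unreadable from compound 1 to compound 2 adds a size. The only regularity is the limit of > 10000 nM in this assay, at which 3 of the 3 values shown sit, for these three compounds, and none of them goes against it. With compound 3 at > 10000 nM as a limit, no step beyond the scatter and no direction can be expected with confidence in this assay for this change. The expected step is a step that the limit leaves unreadable from compound 3 to compound 4 and it rests on limits alone. For compound 4 the estimate is 15000 nM with an expected range from 6000 nM to 40000 nM and another limit is the likeliest report.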

Compound 4, half-maximal cytotoxic concentration: > 10000 nM
Compound 4 ended at the assay's limit; the forecaster's own chance of this, stated with the estimate: 80%; the middle value is on the limit's open side.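

In this assay compound 4 gives > 10000 nM, a limit of the assay and not a number. No step from compound 1, compound 2 or compound 3 to compound 4 can be read, with the whole set at one limit: the limit of > 10000 nM in this assay, at which 4 of the 4 values shown sit.

The compounds shown leave open whether any of the four differs from another in this assay, and at what concentration any of them would turn cytotoxic.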